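The source may hold more compounds than are shown below. What is called first, only, known or untested is meant among the compounds shown, and "the series" means these compounds.

Measured compounds:

compound 1, `CCOC(=O)C1=C(S[C@@H]2CN[C@H](C(=O)Nc3cccc(C(=O)OCC)c3)C2)[C@H](C)[C@@H]2[C@@H]([C@@H](C)OC(=O)CC)C(=O)N12` — in an ADME assay for metabolic stability, read by LC-MS, with a stated time of 3 h, at pH 6.5, tested at 50 uM (a lower number here means that less of the compound is left, a higher number that more of the compound is left), compound 1 gives > 95%, which is a limit of the assay rather than a number.

compound 2, `CC(C)OC(=O)C1=C(S[C@@H]2CN[C@H](C(=O)Nc3cccc(C(=O)OC(C)C)c3)C2)[C@H](C)[C@@H]2[C@@H]([C@@H](C)O)C(=O)N12` — in this assay compound 2 gives > 95%, again a limit of the assay.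

compound 3, `CC(C)c1oc(=O)oc1COC(=O)C1=C(S[C@@H]2CN[C@H](C(=O)Nc3cccc(C(=O)OCc4oc(=O)oc4C(C)C)c3)C2)[C@H](C)[C@@H]2[C@@H]([C@@H](C)O)C(=O)N12` — in this assay compound 3 gives > 95%, again a limit of the assay.

Compound 1 therefore stands at the limit of > 95% in this assay, at which 3 of the 3 values shown sit. Going by the values given here, nothing in these three values sets compound 1 apart from compound 2 or compound 3, and no step between two measured compounds that differ in a single place is available from them.

Compound 4, `CCOC(=O)C1=C(S[C@@H]2CN[C@H](C(=O)Nc3cccc(C(=O)OCC)c3)C2)[C@H](C)[C@@H]2[C@@H]([C@@H](C)OC(C)=O)C(=O)N12`, has not yet been measured. It differs from compound 1 in one place: hydrogen in place of methyl on a saturated chain carbon bound to a carbonyl carbon. Cut one bond further out, the same difference reads propanoyloxy to acetoxy, the ester on the side chain shortening by one carbon.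

With every measured compound, including compound 1, resting at the limit (the limit of > 95% in this assay, at which 3 of the 3 values shown sit), the step from compound 1 to compound 4 is expected to be a number no higher from compound 1 to compound 4 (the limit leaves the size open), that is, none beyond the usual scatter. Compound 4 is thus expected to give about 95% in this assay, between 85% and 99%, most likely again reported only as a limit.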

Compound 4, percent of the compound remaining: > 95%
Compound 4 ended at the assay's limit (the forecaster's own chance of this, stated with the estimate: 70%); the middle value sits exactly at the limit.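

No new step can be read between compound 1 and compound 4 in this assay, because both values are limits of the assay and not numbers: the limit of > 95% in this assay, at which 4 of the 4 values shown sit.

The compounds shown leave open whether propanoyloxy to acetoxy alters the percent of the compound remaining at all, and what would bring any of these compounds off the limit.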